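Swapping the aryl amine of compound 1 for a dimethylphenyl

The source may hold more compounds than are shown below. What is called first, only, known or untested is meant among the compounds shown, and "the series" means these compounds.

Measured compounds:
- compound 1 `CN(c1cccc2c1CN(c1nc(Nc3ccc(Cl)c(C(F)(F)F)c3)ncc1C(F)(F)F)C2)S(C)(=O)=O`: 15200 nM
- compound 2 `COc1cc(N2CCN(C(C)=O)CC2)ccc1Nc1ncc(C(F)(F)F)c(N2Cc3cccc(N(C)S(C)(=O)=O)c3C2)n1`: 3300 nM
- compound 3 `CC(=O)N1CCN(c2ccc(Nc3ncc(C(F)(F)F)c(N4Cc5cccc(N(C)S(C)(=O)=O)c5C4)n3)cc2)CC1`: 1300 nM

In a functional assay on A549 cells (Homo sapiens) for antiproliferative activity, read by spectrophotometry, with a stated time of 2 days (a higher number here means a weaker inhibitor of growth, a lower number a stronger inhibitor of growth), compound 1 gives 15200 nM, the highest of the three numbers, so it is the weakest grower inhibitor of the set. Compound 2 in this assay gives 3300 nM, and compound 3 gives 1300 nM. For the measured compounds named here, the only single-point step among the measured compounds is a 2.5-fold lower number from compound 2 to compound 3 (0.40 log units; beyond the scatter).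

Compound 4 `Cc1ccc(Nc2ncc(C(F)(F)F)c(N3Cc4cccc(N(C)S(C)(=O)=O)c4C3)n2)cc1C` is not yet measured. It differs from compound 1 in one place: 3,4-dimethylphenyl in place of 4-chloro-3-(trifluoromethyl)phenyl on a nitrogen on an aromatic ring. Going by the values given here, no measured step touches this part of the molecule; the one step that exists concerns a methoxy on a different aryl ring, and compounds 2 and 3 carry an acetylpiperazine aryl that compound 4 does not. There is therefore no direct guide, and the change in the aryl group gives no basis for predicting a large move in either direction. The expectation is a step from compound 1 of a 1.3-fold lower number from compound 1 to compound 4 (0.10 log units; within the scatter), near or within the scatter. Compound 4 is thus estimated at 12000 nM, with a range from 3500 nM to 40000 nM.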

Compound 4, concentration for 50% growth inhibition: > 30000 nM
Compound 4 ended at the assay's limit (the forecaster's own chance of this, stated with the estimate: 15%); at least 2.5-fold (0.39 log units) between middle value and limit.
By their numbers in this assay, from the lowest: compound 3; then compound 2; then compound 1. At a limit, above all of these: compound 4.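

In this assay compound 4 gives > 30000 nM, which is a limit of the assay and not a number, so how far its true value lies past that point cannot be read: the limit of > 30000 nM in this assay, at which 1 of the 4 values shown sits.

The step reads an at least 1.9-fold higher number from compound 1 to compound 4 (0.29 log units; that floor lies within the scatter), so at this aryl group on the amine nitrogen, 3,4-dimethylphenyl brings no gain over 4-chloro-3-(trifluoromethyl)phenyl, although the floor of that step does not by itself establish a loss. For the compounds shown here, this is the first look at a simple substituted phenyl other than 4-chloro-3-(trifluoromethyl)phenyl at this position, and neither of these two groups brings the number near that of the acetylpiperazine-bearing compound 3, at 1300 nM.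

The compounds shown leave open whether the chlorine or the trifluoromethyl of the departing group matters more, as the two leave together and a phenyl carrying only one of them does not appear here. They also leave open whether a morpholine or a simple amine on this phenyl ring, in place of the acetylpiperazine, would give a number as low as that of compound 3.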